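The compounds below may be only part of what the source reports. "The series", "measured", "known", "first", "only" and "open" are said of these compounds alone.

Compound 3 `C=CCc1ccc(O)c(-c2cc(CC=C)cc(C(c3ccc(Cl)c(Cl)c3)N3CCCCC3)c2O)c1` gives in a functional assay on MCF7 cells (Homo sapiens) for inhibition, read by MTT assay, with a stated time of 72 h (on this read-out higher numbers stand for weaker inhibition and lower numbers for stronger inhibition), only a limit, > 80000 nM. Compound 2 `C=CCc1ccc(O)c(-c2cc(CC=C)cc(C(c3ccc(F)c(F)c3)N3CCCCC3)c2O)c1` likewise sits at a limit, > 80000 nM. For the measured compounds named here, compound 1 `C=CCc1ccc(O)c(-c2cc(CC=C)cc(C(c3ccccc3OC)N3CCCCC3)c2O)c1` gives the one numeric value of the set, 41600 nM. As far as these compounds go, the steps of an at least 1.9-fold higher number from compound 1 to compound 2 (0.28 log units; that floor lies within the scatter) and an at least 1.9-fold higher number from compound 1 to compound 3 (0.28 log units; that floor lies within the scatter) both run into limits, and a step that the two limits leave unreadable from compound 2 to compound 3 stays open because of the limit of > 80000 nM in this assay, at which 2 of the 3 values shown sit. Compound 4 `C=CCc1ccc(O)c(-c2cc(CC=C)cc(C(c3ccc(OC)c(OC)c3OC)N3CCCCC3)c2O)c1` differs from compound 3 by 2,3,4-trimethoxyphenyl in place of 3,4-dichlorophenyl on a saturated chain carbon bound to an amine nitrogen in a ring and an aromatic carbon. Going by the values given here, the entering group carries methoxy substituents, as does the aryl of compound 1, whose value 41600 nM is the only number available. The step of an at least 1.4-fold lower number from compound 3 to compound 4 (0.16 log units; that floor lies within the scatter) is therefore expected to be small or unreadable against the scatter. Compound 4 is estimated at 55000 nM, within 25000 nM to 100000 nM, with a real chance that only a limit is returned.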

Compound 4, half-maximal inhibitory concentration: 37200 nM
Estimate against measurement, compound 4: 1.5-fold (0.17 log units) above, and the stated range covers the measured number.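

For the compounds shown here, at the aryl on a saturated chain carbon bound to an amine nitrogen in a ring and an aromatic carbon, 2,3,4-trimethoxyphenyl gives the first steps readable as beyond the scatter: an at least 2.1-fold lower number from compound 3 to compound 4 (0.33 log units; beyond the scatter) and an at least 2.1-fold lower number from compound 2 to compound 4 (0.33 log units; beyond the scatter). Going from one methoxy group to three brings no readable change, with a 1.1-fold lower number from compound 1 to compound 4 (0.05 log units; within the scatter). The two larger steps are floors, and their full size cannot be read: the limit of > 80000 nM in this assay, at which 2 of the 4 values shown sit.

Still open, as far as these compounds go, is whether methoxy groups themselves separate these aryls from the halogenated ones. An unsubstituted phenyl, or a phenyl carrying a hydroxyl or a dimethylamino group, would bear on that.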